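A few compounds are considered here, and "the series" means these few. Any claim that something is new, unique, unknown or untested is made for them only; others in the source may bear on it.

Measured compounds:
- compound 1, `Nc1nc(=O)ccn1[C@@H]1O[C@H](COP(=O)(O)OP(=O)(O)O)[C@@H](O)[C@H]1O`, gives in an in vitro functional assay on 1321-N1 cells for agonist activity at P2Y purinoceptor 6 (Homo sapiens), read by scintillation proximity assay and inositol phosphate accumulation (a higher number here means that more compound is needed for the effect, a lower number that less compound is needed), a value of >= 100000 nM.
- compound 2, `O=c1ccn([C@@H]2O[C@H](COP(=O)(O)O)[C@@H](O)[C@H]2O)c(SCCc2ccccc2)n1`, gives > 100000 nM.
- compound 3, `CCCSc1nc(=O)ccn1[C@@H]1O[C@H](COP(=O)(O)OP(=O)(O)O)[C@@H](O)[C@H]1O`, gives >= 100000 nM.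

All three values are limits of this assay, not numbers. The value of compound 1 is a limit. The value of compound 2 is a limit. The value of compound 3 is a limit as well, so compound 3 stands at the edge of what this assay can report, where the limit of >= 100000 nM in this assay, at which 2 of the 3 values shown sit, and the limit of > 100000 nM in this assay, at which 1 of the 3 values shown sits, together place every measured compound.

Among the compounds with values here, the one measured step that differs in a single place, a step that the two limits leave unreadable from compound 1 to compound 3, cannot be read in size, since both of its ends are limits.

Compound 4, `O=c1ccn([C@@H]2O[C@H](COP(=O)(O)OP(=O)(O)O)[C@@H](O)[C@H]2O)c(SCCc2ccccc2)n1`, differs from compound 3 by phenyl in place of methyl on a saturated chain carbon, two bonds along the chain from a sulfur. Within the data shown here, no measured step bears on this change in a readable way: the step from compound 1 to compound 3 gives no size, and compound 2, which carries the same phenethylsulfanyl group on a monophosphate, gives only a limit. With nothing to point in either direction, the expectation for compound 4 is a step of a number no higher from compound 3 to compound 4 (the limit leaves the size open), that is, none beyond the scatter. Compound 4 is therefore estimated at 100000 nM in this assay, within a range from 20000 nM to 500000 nM, most likely again reported only as a limit.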

Compound 4, half-maximal effective concentration: 2500 nM
The estimate for compound 4 lay 40-fold (1.60 log units) above the measured number; measured number below the stated range.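

In this assay, phenyl in place of methyl on a saturated chain carbon, two bonds along the chain from a sulfur, turns a compound that stays at a limit into the only one here with a readable number, giving an at least 40-fold lower number from compound 3 to compound 4 (1.60 log units; beyond the scatter). The phenethylsulfanyl group is not enough on its own, as the group of 3 oxygen atoms and 1 phosphorus atom in place of a hydrogen atom, on an oxygen, gives an at least 40-fold lower number from compound 2 to compound 4 (1.60 log units; beyond the scatter). Starting from the amino group instead gives an at least 40-fold lower number from compound 1 to compound 4 (1.60 log units; beyond the scatter), and all three steps start from limits, so their full size stays open: the limit of >= 100000 nM in this assay, at which 2 of the 4 values shown sit.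

With a single compound giving a number, these compounds cannot tell how much of the chain and the phenyl ring is needed, for instance whether benzylsulfanyl, a longer phenylpropylsulfanyl chain, or a phenyl ring carrying a chlorine or a methoxy group would keep the effect. They also leave open why the phenyl ring and the added phosphate group matter, and whether a cyclohexyl ring or an amine at the end of the chain could take the place of phenyl.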